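Piperidine nitrogen substituents and dopamine transporter binding

The source may report more compounds than this note shows. Statements on the series, on what has been measured and on what is new or still open speak of the compounds shown alone.

Measured compounds:
compound 1 `Fc1ccc(CN2CCC(NCCSC(c3ccc(F)cc3)c3ccc(F)cc3)CC2)cc1` — 25.5 nM
compound 2 `CC(C)(C)CN1CCC(NCCSC(c2ccc(F)cc2)c2ccc(F)cc2)CC1` — 279 nM

In an assay on membranes from striatum (strain Sprague-Dawley) for displacement of a labelled ligand from sodium-dependent dopamine transporter (Rattus norvegicus), read by scintillation counting, with a stated time of 120 min (on this read-out lower numbers stand for stronger inhibition and higher numbers for weaker inhibition), compound 2 gives the highest of the two numbers, with compound 1 as its nearest neighbour at a step of an 11-fold higher number from compound 1 to compound 2 (1.04 log units; beyond the scatter). Compound 3 `O=C(c1ccc(F)cc1F)N1CCC(NCCSC(c2ccc(F)cc2)c2ccc(F)cc2)CC1` arises from compound 2 by the change ((2,4-difluorophenyl)carbonyl in place of neopentyl on an amine nitrogen in a ring). Among the measured compounds shown here, the only measured step that bears on this, an 11-fold higher number from compound 1 to compound 2 (1.04 log units; beyond the scatter), was large and followed the loss of an aromatic ring from the same position; the present change brings an aromatic ring back, though joined through a carbonyl rather than a saturated chain carbon. A lower number is therefore expected for compound 3, estimated at 70 nM (range 15 nM to 320 nM), a step of a 4.0-fold lower number from compound 2 to compound 3 (0.60 log units; beyond the scatter) from compound 2.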

Compound 3, inhibition constant: 30 nM
For compound 3 the middle estimate is 2.3-fold (0.37 log units) above the measured one, within the range that was stated.
By their numbers in this assay, from the lowest: compounds 1 and 3 (each within the scatter of the next); then compound 2.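

In this assay, placing (2,4-difluorophenyl)carbonyl on the ring amine nitrogen in place of neopentyl gives a 9.3-fold lower number from compound 2 to compound 3 (0.97 log units; beyond the scatter). Set against 4-fluorobenzyl, the same group gives a 1.2-fold higher number from compound 1 to compound 3 (0.07 log units; within the scatter), so this read-out does not separate the carbonyl link to an aromatic ring from the saturated chain carbon link in these two compounds. No supporting evidence accounts for this result. As far as these compounds go, it remains open whether the two fluorines matter relative to an unsubstituted benzoyl group, and whether a pyridine ring could replace the fluorinated benzene ring.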